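The source may report more compounds than this note shows. Statements on the series, on what has been measured and on what is new or still open speak of the compounds shown alone.

In a functional assay on A-431 cells (Homo sapiens) for antiproliferative activity, read by sulforhodamine B assay, with a stated time of 72 h (on this read-out lower numbers stand for stronger inhibition and higher numbers for weaker inhibition), the measured compounds gave these values:

compound 1 `C=C1CC(CI)(c2ccccc2)OC1=O` gives 2720 nM
compound 2 `C=C1CC(CI)(c2ccc(F)cc2)OC1=O` gives 1900 nM
compound 3 `C=C1CC(C[Se]c2ccccc2)(c2ccccc2)OC1=O` gives 1270 nM

Among the compounds with values here, compound 1 stands at the upper end of these numbers, yet only one measured step from it goes beyond the scatter, and only modestly (a 2.1-fold lower number from compound 1 to compound 3 (0.33 log units; beyond the scatter)). The other measured step stays within the scatter (a 1.4-fold lower number from compound 1 to compound 2 (0.16 log units; within the scatter)).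

Compound 4 `C=C1CC(c2ccccc2)(C(C)Br)OC1=O` has not yet been measured. Its change from compound 1 is 1-bromoethyl in place of iodomethyl on a saturated ring carbon. Within the data shown here, no measured step makes this exchange. Among the measured compounds shown here, the closest precedent is compound 3, which also replaces the iodomethyl group, and its step was modest (a 2.1-fold lower number from compound 1 to compound 3 (0.33 log units; beyond the scatter)). The fluoro step to compound 2 concerns an aromatic carbon and bears on this change only weakly. No step beyond the scatter is therefore expected, and the data suggest no firm direction.

For compound 4 the estimated step is a 1.0-fold higher number from compound 1 to compound 4 (0.01 log units; within the scatter), a small one.

For compound 4 the expected value is 2800 nM (estimated range 1100 nM to 7000 nM).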

Compound 4, half-maximal inhibitory concentration: 5240 nM
Estimate against measurement, compound 4: 1.9-fold (0.27 log units) below, and the stated range covers the measured number.
By their numbers in this assay, from the lowest: compounds 3, 2, 1 and 4 (each within the scatter of the next, the first and the last beyond it).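

In this assay, 1-bromoethyl in place of iodomethyl on a saturated ring carbon, next to the ring oxygen, gives a 1.9-fold higher number from compound 1 to compound 4 (0.28 log units; within the scatter) and so stays within the scatter. The only other exchange of iodomethyl shown gives a 2.1-fold lower number from compound 1 to compound 3 (0.33 log units; beyond the scatter) and lies beyond the scatter, so not every exchange of this group moves the number that far. Nothing available explains either result.

The compounds shown do not separate the change of halogen from the change of chain, since 1-bromoethyl differs from iodomethyl in both. On these data alone, a bromomethyl group would address that question, while an aminomethyl group would show how this position responds to a nitrogen-bearing chain, and both remain open.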